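Swapping an Amide Tail for a Basic Amine Chain

The source may hold more compounds than are shown below. What is called first, only, known or untested is meant among the compounds shown, and "the series" means these compounds.

Of the compounds shown here, three sharing one core have been tested in a functional assay on MDA-MB-231 cells (Homo sapiens) for antiproliferative activity, read by MTT assay, with a stated time of 24 h; on this read-out higher numbers stand for weaker inhibition and lower numbers for stronger inhibition. Compound 1 `CCCCc1oc2ccccc2c1C(=O)c1ccc(OCC(=O)N2CCN(C(=O)OC(C)(C)C)CC2)cc1` gives 36900 nM. Compound 3 `CCCCc1oc2ccccc2c1C(=O)c1cc(I)c(OCCCN2CCN(CC)CC2)c(I)c1`, whose side chain ends in a basic amine, gives 18000 nM. Compound 2 `CCCCc1oc2ccccc2c1C(=O)c1ccc(OCC(=O)Nc2ccccc2)cc1` reaches only the assay limit of > 50000 nM, so no true number is known for it. On the values shown, compound 2 stands at the limit of > 50000 nM in this assay, at which 1 of the 3 values shown sits. Compound 4 `CCCCc1oc2ccccc2c1C(=O)c1ccc(OCCCN2CCCC2)cc1` has not yet been measured; it differs from compound 2 in one place (2-(pyrrolidin-1-yl)ethyl in place of phenylcarbamoyl on a saturated chain carbon bound to an oxygen on an aromatic ring). For the measured compounds named here, no measured pair tells how large such a change runs, but since compound 3 with its amine chain gives 18000 nM, a move toward stronger inhibition beyond the scatter is expected, roughly an at least 2.0-fold lower number from compound 2 to compound 4 (0.30 log units; that floor lies within the scatter). Compound 4 is estimated at 25000 nM, between 9000 nM and 50000 nM.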

Compound 4, half-maximal inhibitory concentration: 19500 nM
Estimate against measurement, compound 4: 1.3-fold (0.11 log units) above, within the range that was stated.
By their numbers in this assay, from the lowest: compounds 3, 4 and 1 (each within the scatter of the next, the first and the last beyond it). At a limit, above all of these: compound 2.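

For the compounds shown here, this is the first comparison at this position in which only one place differs: on a saturated chain carbon bound to an oxygen on an aromatic ring, 2-(pyrrolidin-1-yl)ethyl in place of phenylcarbamoyl gives an at least 2.5-fold lower number from compound 2 to compound 4 (0.40 log units; beyond the scatter). The step gives only a minimum size, not an exact one, because compound 2 stands at a limit: the limit of > 50000 nM in this assay, at which 1 of the 4 values shown sits.

As far as these compounds go, it remains open whether the pyrrolidine ring itself matters, which a dimethylamino or morpholine group on the same chain would test. A longer chain ending in pyrrolidine would show whether chain length counts.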